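This account rests on a few compounds, and the source may have more. Where it says the series, first, only, none or still open, it means among the compounds named here.

Compound 3 `CN(C)C1=Nc2ccccc2C(CC(=O)NCc2ccc(N)cc2)N1c1ccccc1` has been measured in a functional assay on HT-29 cells (Homo sapiens) for inhibition, read by sulforhodamine B assay, with a stated time of 72 h (a higher number here means a weaker inhibitor of growth, a lower number a stronger inhibitor of growth), where compound 3 gives 28300 nM. That is the highest of the three numbers recorded so far: compound 2 `CCN1C(N2CCCCC2)=Nc2ccccc2C1CC(=O)NCc1ccc(NS(=O)(=O)c2ccc(F)cc2)cc1` gives 13900 nM in this assay, and compound 1 `O=C(CC1c2ccccc2N=C(N2CCCCC2)N1c1ccccc1)NCc1ccc(NS(=O)(=O)c2ccc(F)cc2)cc1` gives 1710 nM. For the measured compounds named here, the only step between measured compounds that differ in one place is an 8.1-fold higher number from compound 1 to compound 2 (0.91 log units; beyond the scatter), and that step concerns the group on a ring nitrogen of the shared core, not the group on the 4-aminobenzyl portion. Compound 4 `CN(C)C1=Nc2ccccc2C(CC(=O)NCc2ccc([N+](=O)[O-])cc2)N1c1ccccc1` differs from compound 3 by nitro in place of amino on an aromatic carbon. Going by the values given here, no measured step touches this part of the molecule, so the data give no indication of whether a nitro group in this place raises or lowers the number in this assay; the expectation is therefore a step of a 1.1-fold lower number from compound 3 to compound 4 (0.05 log units; within the scatter), with no change beyond the scatter the most defensible reading. On that basis compound 4 is estimated at 25000 nM in this assay, with a likely range from 8000 nM to 80000 nM.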

Compound 4, concentration for 50% growth inhibition: 22300 nM
Compound 4: middle estimate off by 1.1-fold (0.05 log units), on the high side, and the stated range covers the measured number.
By their numbers in this assay, from the lowest: compound 1; then compounds 2, 4 and 3 (each within the scatter of the next, the first and the last beyond it).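

In this assay, replacing amino with nitro on the aromatic carbon gives a 1.3-fold lower number from compound 3 to compound 4 (0.10 log units; within the scatter), so this pair cannot be told apart. For the compounds shown here, this is the first reading at this position, and it shows that a hydrogen-bond donor and a small group can give way to a larger group with no donor without moving the number beyond the scatter, at least on this scaffold. No measured property of these compounds is available to explain this result.

On these data alone, whether a methoxy group or a chlorine atom on the same carbon would also leave the number unchanged remains open. Compound 1 and compound 2 carry a 4-fluorophenyl sulfonamide here but differ from compound 3 in more than one place, so the contribution of that group at this position cannot be read.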